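This account rests on a few compounds, and the source may have more. Where it says the series, first, only, none or still open, it means among the compounds named here.

Of the compounds shown here, three have been measured in an assay on microsomes from intestine for inhibition of acyl-CoA:cholesterol acyltransferase (Oryctolagus cuniculus); on this read-out higher numbers stand for weaker inhibition and lower numbers for stronger inhibition. Compound 1 `CCCCCCCC/C=C/CCCCCCCC(=O)Nc1c(C)cccc1C(C)C` gives 23 nM, and compound 2 `CCCCCCCC/C=C/CCCCCCC(C)C(=O)Nc1c(OC)cc(OC)cc1OC` gives 36 nM. Compound 3 `CCCCCCCCCCC(C)(C)C(=O)Nc1c(OC)cc(OC)cc1OCC(=O)OC` gives 2300 nM, the highest number of the three and beyond the scatter from both compound 1 and compound 2, so it is the weakest inhibitor among them.

The next compound, compound 4 `CCCCCCCCCCC(C)(C)C(=O)Nc1c(OC)cc(OC)cc1OCCCCCCC`, differs from compound 3 in one place: hexyl in place of methoxycarbonyl on a saturated chain carbon bound to an oxygen on an aromatic ring. Among the compounds with values here, no measured pair shows this exact change, so the step can only be expected, not read off. Because compound 3 sits at 2300 nM while the two compounds carrying long saturated chains sit far lower, a step toward a lower number is expected, of size a 7.7-fold lower number from compound 3 to compound 4 (0.88 log units; beyond the scatter), beyond the scatter. Compound 4 is therefore estimated at 300 nM, with a range from 50 nM to 2000 nM.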

Compound 4, half-maximal inhibitory concentration: 140 nM
For compound 4 the middle estimate is 2.1-fold (0.33 log units) above the measured one, within the range that was stated.
By their numbers in this assay, from the lowest: compounds 1 and 2 (each within the scatter of the next); then compound 4; then compound 3.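

In this assay, the place on a saturated chain carbon bound to an oxygen on an aromatic ring responds strongly to what it carries: hexyl in place of methoxycarbonyl gives a 16-fold lower number from compound 3 to compound 4 (1.22 log units; beyond the scatter). Within the data shown here, this is the first comparison here of compounds that differ in one place, and it shows that this position matters for inhibition. Nothing available explains why the step is so large.

From the compounds shown here alone, whether removing methoxycarbonyl or adding hexyl drives the step remains open. A carboxylic acid, an amine or a longer chain at this place could help separate the two.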